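A few compounds are considered here, and "the series" means these few. Any claim that something is new, unique, unknown or untested is made for them only; others in the source may bear on it.

Measured in an ADME assay on L02 cells (Homo sapiens) for cytotoxicity, read by MTT assay, with a stated time of 24 h; a lower number here means a stronger inhibitor, a higher number a weaker inhibitor:

- compound 1 `COc1cc(/C=C2\CN(C)C/C(=C\c3ccc(Br)cc3)C2=O)cc(OC)c1OC`: 15400 nM
- compound 2 `COc1cc(/C=C2\CN(C)C/C(=C\c3ccc(Cl)cc3Cl)C2=O)cc(OC)c1OC`: 13400 nM
- compound 3 `CN1C/C(=C\c2ccc(Br)cc2)C(=O)/C(=C/c2cccc([N+](=O)[O-])c2)C1`: 9850 nM

Working notes on the series. Compound 1 and compound 2 share one core and differ in a single place: 2,4-dichlorophenyl in place of 4-bromophenyl on a double-bonded chain carbon bound to a double-bonded ring carbon. In this assay this change made a step of a 1.1-fold lower number from compound 1 to compound 2 (0.06 log units; within the scatter), so on the core of compound 1 the two values are not told apart by the assay.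

Compound 3 carries a different core; the difference between the core of compound 3 and the core of compound 1 is not broken down here. The values of compound 1 and compound 3 in this assay lie within the scatter of each other, as do those of compound 2 and compound 3, so no order among the three measured compounds can be read from these numbers.

Compound 4 `CN1C/C(=C\c2cccc([N+](=O)[O-])c2)C(=O)/C(=C/c2ccc(Cl)cc2Cl)C1` has not yet been measured. It is compound 3 with 2,4-dichlorophenyl in place of 4-bromophenyl on a double-bonded chain carbon bound to a double-bonded ring carbon. The place of this change is worded the same as the place of the change from compound 1 to compound 2, so it is the same change carried onto the core of compound 3. In this assay compound 4 is expected to sit close to compound 3, with an estimated step of a 1.1-fold lower number from compound 3 to compound 4 (0.04 log units; within the scatter), because the only earlier record of this change is a 1.1-fold lower number from compound 1 to compound 2 (0.06 log units; within the scatter) and that step stayed within the scatter. The estimate for compound 4 in this assay is 9000 nM, with an expected range from 4500 nM to 18000 nM, the width resting on a single prior example of the change on another core.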

Compound 4, half-maximal inhibitory concentration: 14000 nM
Compound 4: middle estimate off by 1.6-fold (0.19 log units), on the low side; the range from low to high includes it.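

Carried onto the second core, 2,4-dichlorophenyl in place of 4-bromophenyl gives a 1.4-fold higher number from compound 3 to compound 4 (0.15 log units; within the scatter) in this assay, and this step does not differ from the earlier one: the same change on two cores in this assay, a 1.1-fold lower number (0.06 log units; within the scatter) from compound 1 to compound 2 and a 1.4-fold higher number (0.15 log units; within the scatter) from compound 3 to compound 4, 1.6-fold (0.21 log units) apart, within the scatter of two such steps. On these two cores, then, the change leaves the number within the scatter, and the two records agree on that point. This does not show that the change is without effect in general, since the assay cannot resolve steps of this size, no direction can be assigned to it, and two pairs say nothing about any other core in the series.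

Every step read so far lies within the scatter, so the compounds shown do not reveal which part of the structure, if any, can move the number in this assay. The aryl groups in this change are a halogen-bearing phenyl on each side, which leaves open whether an amine or a carboxylic acid in place of the halogens, or a longer chain in place of the methyl on the core nitrogen, would give a step beyond the scatter.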